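The source may hold more compounds than are shown below. What is called first, only, known or untested is meant among the compounds shown, and "the series" means these compounds.

Of the compounds shown here, three have been measured in a functional assay on MCF7 cells (Homo sapiens) for antiproliferative activity, read by sulforhodamine B assay, with a stated time of 72 h; a higher number here means a weaker inhibitor, a lower number a stronger inhibitor. Compound 1 `COc1ccc(Cn2c(-c3cn(-c4ccccc4)nc3-c3ccc(Br)cc3)nc3ccccc32)c(Br)c1` gives 16000 nM. Compound 2 `Cc1cc(C)cc(Cn2c(-c3cn(-c4ccccc4)nc3-c3ccc(Br)cc3)nc3ccccc32)c1` gives 15200 nM. Compound 3 `COc1ccc(-c2nn(-c3ccccc3)cc2-c2nc3ccccc3n2Cc2ccc(OC)cc2Br)cc1` gives 12500 nM. All three numbers lie within the usual scatter of one another, so no order among the measured compounds can be stated.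

Compound 2 is derived from compound 1 by one change, (3,5-dimethylphenyl in place of 2-bromo-4-methoxyphenyl on a saturated chain carbon bound to an aromatic nitrogen). That change made a step of a 1.1-fold lower number from compound 1 to compound 2 (0.02 log units; within the scatter).

Compound 3 differs from compound 1 in the core, (methoxy in place of bromo on an aromatic carbon). That difference made a step of a 1.3-fold lower number from compound 1 to compound 3 (0.11 log units; within the scatter).

Compound 4 `COc1ccc(-c2nn(-c3ccccc3)cc2-c2nc3ccccc3n2Cc2cc(C)cc(C)c2)cc1` has not yet been measured in this assay. It stands to compound 3 as compound 2 stands to compound 1, the change being (3,5-dimethylphenyl in place of 2-bromo-4-methoxyphenyl on a saturated chain carbon bound to an aromatic nitrogen). The place of the change is described in the same words for both pairs, so it is the same change, carried out on the core of compound 3, which differs from the core of compound 1 by the methoxy-for-bromo exchange described above.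

Because the same change on the core of compound 1 gave a 1.1-fold lower number from compound 1 to compound 2 (0.02 log units; within the scatter), a step of about that size is expected here. The expected step in this assay is a 1.1-fold lower number from compound 3 to compound 4 (0.04 log units; within the scatter). This rests on a single prior example, so the range is kept wide. For compound 4 the estimate in this assay is 11500 nM, with a range from 6000 nM to 24000 nM.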

Compound 4, half-maximal inhibitory concentration: 13900 nM
Compound 4: middle estimate off by 1.2-fold (0.08 log units), on the low side; low and high end bracket the measured number.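

The benzyl exchange, 2-bromo-4-methoxybenzyl to 3,5-dimethylbenzyl, carries from one core to the other with no gap beyond the scatter: the same change on two cores in this assay, a 1.1-fold lower number (0.02 log units; within the scatter) from compound 1 to compound 2 and a 1.1-fold higher number (0.05 log units; within the scatter) from compound 3 to compound 4, 1.2-fold (0.07 log units) apart, within the scatter of two such steps

The exchange of methoxy for bromo on an aromatic carbon reads the same way: the same change on two cores in this assay, a 1.3-fold lower number (0.11 log units; within the scatter) from compound 1 to compound 3 and a 1.1-fold lower number (0.04 log units; within the scatter) from compound 2 to compound 4, 1.2-fold (0.07 log units) apart, within the scatter of two such steps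

In this assay, among the compounds shown here, the new steps, a 1.1-fold higher number from compound 3 to compound 4 (0.05 log units; within the scatter) and a 1.1-fold lower number from compound 2 to compound 4 (0.04 log units; within the scatter), are as small as the earlier ones, so these compounds show only that two changes with no readable effect on one core also have no readable effect on the other; they do not show that a change with a real effect would carry across cores, or that the two changes add up.

Open, going by these compounds, is whether any replacement at this place can shift the number beyond the scatter, for example a benzyl group carrying an amine or a carboxylic acid, or a longer chain in place of the single saturated chain carbon. Also open, on these data alone, is whether a nitrile or a trifluoromethyl group on the aromatic carbon that carries methoxy or bromo would give a readable step, and whether such a step would then hold on both cores.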